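Methylsulfanyl in place of propargylsulfanyl on a phthalimide-triazole

A few compounds are considered here, and "the series" means these few. Any claim that something is new, unique, unknown or untested is made for them only; others in the source may bear on it.

Compound 1, `CCc1nnc(SC)n1N1C(=O)c2ccccc2C1=O`, gives > 200000 nM in a functional assay on PC-3M cells (Homo sapiens) for cytotoxicity, read by MTT assay, with a stated time of 48 h (a lower number here means a stronger inhibitor, a higher number a weaker inhibitor), which is a limit of the assay.
Compound 2, `CCCc1nnc(SCC(=O)c2ccc(C)cc2)n1N1C(=O)c2ccccc2C1=O`, gives > 200000 nM in this assay, again a limit.
Compound 3, `C#CCSc1nnc(CCC)n1N1C(=O)c2ccccc2C1=O`, gives > 200000 nM in this assay, also a limit.

Compound 3 therefore stands only at a limit, and the two other values shown are limits as well, as the limit of > 200000 nM in this assay, at which 3 of the 3 values shown sit, states. Among the measured compounds shown here, the one measured step, a step that the two limits leave unreadable from compound 2 to compound 3, cannot be read for the same reason. Compound 4, `CCCc1nnc(SC)n1N1C(=O)c2ccccc2C1=O`, differs from compound 3 by hydrogen in place of ethynyl on a saturated chain carbon bound to a sulfur. For the measured compounds named here, no measured step bears readably on this change, so no direction can be drawn from it. Given that compound 1 with its methylsulfanyl group sits at > 200000 nM, compound 4 is expected to remain at the limit, a step that the limit leaves unreadable from compound 3 to compound 4. The estimate for compound 4 is 300000 nM, within 150000 nM to 1000000 nM.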

Compound 4, half-maximal inhibitory concentration: > 200000 nM
Compound 4 was reported as a limit; the forecaster's own chance of this, stated with the estimate: 90%; the middle value lies beyond the limit too.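

The steps linking compound 4 to compound 1, compound 2 and compound 3 cannot be read, because all four results are limits of the assay: the limit of > 200000 nM in this assay, at which 4 of the 4 values shown sit.

The compounds shown leave open which change to the shared core, if any, would give a measurable value in this assay.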